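Compound 2 and the step to a 3-chlorophenyl analogue

A few compounds are considered here, and "the series" means these few. Any claim that something is new, unique, unknown or untested is made for them only; others in the source may bear on it.

Compound 1 `COc1ccccc1Oc1c(N)nc(-c2ccccc2)nc1Cl` gives 3140 nM
Compound 2 `COc1ccccc1Oc1c(N)nc(-c2ccc(F)cc2)nc1Cl` gives 31900 nM

For the measured compounds named here, in a functional assay on SK-MEL-28 cells (Homo sapiens) for cytotoxicity, read by CCK-8 assay, with a stated time of 24 h (on this read-out lower numbers stand for stronger inhibition and higher numbers for weaker inhibition), compound 2 holds the higher of the two numbers, with compound 1 as its only neighbour. Compound 3 `COc1ccccc1Oc1c(N)nc(-c2cccc(Cl)c2)nc1Cl` is still unmeasured. It carries 3-chlorophenyl in place of 4-fluorophenyl on an aromatic carbon. Going by the values given here, one measured step bears on this change: a 10-fold higher number from compound 1 to compound 2 (1.01 log units; beyond the scatter), a large step beyond the scatter, with fluoro in place of hydrogen on an aromatic carbon. Among the compounds with values here, compound 3 has no fluoro group, but no measured step shows what its chloro group does, so a moderate move to a lower number is expected in this assay, probably short of a full return to the number of compound 1. The expected step is a 3.5-fold lower number from compound 2 to compound 3 (0.55 log units; beyond the scatter), and it is only a rough estimate. For compound 3 the estimated value is 9000 nM, with an expected range of 2000 nM to 40000 nM.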

Compound 3, half-maximal inhibitory concentration: 19400 nM
Estimate against measurement, compound 3: 2.2-fold (0.33 log units) below, and the stated range covers the measured number.
By their numbers in this assay, from the lowest: compound 1; then compounds 3 and 2 (each within the scatter of the next).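

In this assay, exchanging 4-fluorophenyl for 3-chlorophenyl makes no difference that can be told from the scatter (a 1.6-fold lower number from compound 2 to compound 3 (0.22 log units; within the scatter)), so this change does not separate compound 2 from compound 3. Chloro in place of hydrogen on the phenyl ring, however, gives a step beyond the scatter (a 6.2-fold higher number from compound 1 to compound 3 (0.79 log units; beyond the scatter)), so the move away from compound 1 is no longer seen with fluoro alone: both halogen-bearing compounds stand apart from the unsubstituted phenyl of compound 1. No measurement shown offers an explanation for these numbers.

The exchange alters both the halogen and its place on the phenyl ring, and the compounds shown do not separate these two changes. They also leave open how a non-halogen group on that ring, such as methoxy or an amine, would compare with the plain phenyl of compound 1.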